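Trimming the outer substituent in the cytotoxicity series

This account rests on a few compounds, and the source may have more. Where it says the series, first, only, none or still open, it means among the compounds named here.

Two compounds of the shared core have been run in a functional assay on HCT-116 cells (Homo sapiens) for cytotoxicity, read by MTT assay, with a stated time of 48 h; on this read-out higher numbers stand for weaker inhibition and lower numbers for stronger inhibition. Compound 1 `CCN(CC)c1ccc2cc(C(=O)c3ccc(N4CCN(C(=O)CN5CCN(C(=O)CCl)CC5)CC4)cc3)oc2c1` returns only a limit of the assay, not a number: in this assay compound 1 sits at > 40000 nM. Among the measured compounds shown here, compound 2 `CCN(CC)c1ccc2cc(C(=O)c3ccc(N4CCN(C(=O)CN5CCN(Cc6ccc(/C=C/C(=O)OC)cc6)CC5)CC4)cc3)oc2c1` gives the one real number of the set, and in this assay compound 2 shows 9920 nM. Compound 2 therefore stands alone: the other result is a limit (the limit of > 40000 nM in this assay, at which 1 of the 2 values shown sits), so nothing measured ranks it up or down.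

Compound 3 `CCN(CC)c1ccc2cc(C(=O)c3ccc(N4CCN(C(=O)CN5CCN(CC(C)=O)CC5)CC4)cc3)oc2c1` awaits measurement. It differs from compound 2 by acetyl in place of 4-(2-(methoxycarbonyl)ethenyl)phenyl on a saturated chain carbon bound to an amine nitrogen in a ring — acetyl in place of 4-(2-(methoxycarbonyl)ethenyl)phenyl on a saturated chain carbon bound to an amine nitrogen in a ring. For the measured compounds named here, no measured pair covers such a change, so the step size rests on the shape of the series only. Going by the values given here, the one compound carrying a small group at that place, compound 1, reached only the limit in this assay. The expected step of a 3.0-fold higher number from compound 2 to compound 3 (0.48 log units; beyond the scatter) is estimated to run towards weaker inhibition, beyond the scatter. Compound 3 is expected at 30000 nM, with a range from 10000 nM to 80000 nM, and a real chance that only a limit is reported.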

Compound 3, half-maximal inhibitory concentration: 24000 nM
Beside the measured number, compound 3's estimate is 1.3-fold (0.10 log units) above it; the range from low to high includes it.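

In this assay, replacing 4-(2-(methoxycarbonyl)ethenyl)phenyl with acetyl on a saturated chain carbon bound to an amine nitrogen in a ring gives a 2.4-fold higher number from compound 2 to compound 3 (0.38 log units; beyond the scatter), the first readable size for a change at this place, and a modest one given how much of the group leaves. The acetyl-bearing compound 3 still returns a real number, so the full 4-(2-(methoxycarbonyl)ethenyl)phenyl group is not required for a measurable value in this series. The other comparison, 2-oxopropyl in place of (chloromethyl)carbonyl on an amine nitrogen in a ring, gives an at least 1.6-fold lower number from compound 1 to compound 3 (0.22 log units; that floor lies within the scatter), so it fixes no order, and compound 1 remains a limit of the assay rather than a number: the limit of > 40000 nM in this assay, at which 1 of the 3 values shown sits.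

Which part of the departing group carries the step remains open: the aromatic ring, the ethenyl link or the methyl ester. A plain phenyl group, a carboxylic acid in place of the methyl ester, or a simple amine on the same chain carbon would begin to separate these parts.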